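The source may report more compounds than this note shows. Statements on the series, on what has been measured and on what is new or still open speak of the compounds shown alone.

Measured so far in a functional assay on HepG2 cells (Homo sapiens) for antiproliferative activity, read by CCK-8 assay, with a stated time of 72 h; on this read-out lower numbers stand for stronger inhibition and higher numbers for weaker inhibition:
compound 1 `Cc1ccc(C(=O)Nc2cccc(-c3oc4cc(-c5ccc(F)cc5)ccc4c(=O)c3O)c2)cc1`, 2320 nM
compound 2 `O=C(Nc1cccc(-c2oc3cc(-c4ccc(F)cc4)ccc3c(=O)c2O)c1)c1ccc(F)cc1F`, 26400 nM

Compound 1 stands lowest of the two numbers shown; its nearest neighbour is compound 2, reached by an 11-fold higher number from compound 1 to compound 2 (1.06 log units; beyond the scatter). Compound 3 `CCCc1ccc(C(=O)Nc2cccc(-c3oc4cc(-c5ccc(F)cc5)ccc4c(=O)c3O)c2)cc1` differs from compound 1 by ethyl in place of hydrogen on a saturated chain carbon bound to an aromatic carbon. Within the data shown here, no measured step bears on this change: the only step available concerns a different group on the carbonyl carbon, so its size says nothing about a longer chain at this place. Compound 3 is therefore expected to show a 1.1-fold higher number from compound 1 to compound 3 (0.03 log units; within the scatter) in this assay, a step not clearly beyond the scatter. Compound 3 is estimated at 2500 nM, within 900 nM to 7000 nM.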

Compound 3, half-maximal inhibitory concentration: 51500 nM
For compound 3 the middle estimate is 21-fold (1.31 log units) below the measured one; measured number outside the range, above it.
By their numbers in this assay, from the lowest: compound 1; then compounds 2 and 3 (each within the scatter of the next).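

Lengthening methyl to propyl at this place is not a silent change: in this assay it gives a 22-fold higher number from compound 1 to compound 3 (1.35 log units; beyond the scatter). The second comparison, a 2.0-fold higher number from compound 2 to compound 3 (0.29 log units; within the scatter), stays within the scatter, so 4-propylphenyl and 2,4-difluorophenyl on the carbonyl carbon cannot be told apart, and compound 1 stands alone at the low end of the three. Nothing available here accounts for this rise.

Still open, going by these compounds, is whether an ethyl chain, or an amine or a carboxylic acid in place of the methyl, would stay near compound 1. Also open, on these data alone, is whether a longer chain than propyl would raise the number further.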